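The compounds below may be only part of what the source reports. "The series", "measured", "known", "first", "only" and "open" are said of these compounds alone.

Measured compounds:
compound 1, `Cc1cc(S(=O)(=O)/N=C(\N)N/N=C/C#Cc2ccccc2)c(SCc2ccccc2)cc1Cl`, 24000 nM
compound 2, `Cc1cccc(CSc2cc(Cl)c(C)cc2S(=O)(=O)/N=C(\N)N/N=C/C#Cc2ccccc2)c1`, 16000 nM
compound 3, `Cc1cc(S(=O)(=O)/N=C(\N)N/N=C/C#Cc2ccccc2)c(SCc2ccc(C(F)(F)F)cc2)cc1Cl`, 105000 nM

In a functional assay on MCF7 cells (Homo sapiens) for antiproliferative activity, read by MTT assay, with a stated time of 72 h (on this read-out lower numbers stand for stronger inhibition and higher numbers for weaker inhibition), compound 3 gives the highest number of the three. Its neighbours sit well apart from it: the step of a 4.4-fold higher number from compound 1 to compound 3 (0.64 log units; beyond the scatter) and the step of a 6.6-fold higher number from compound 2 to compound 3 (0.82 log units; beyond the scatter) are both beyond the scatter, whereas the step of a 1.5-fold lower number from compound 1 to compound 2 (0.18 log units; within the scatter) stays within it. Compound 4, `Cc1cc(S(=O)(=O)/N=C(\N)N/N=C/C#Cc2ccccc2)c(SCc2ccc(Cl)cc2)cc1Cl`, is not yet measured; it differs from compound 3 by chloro in place of trifluoromethyl on an aromatic carbon.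

Among the measured compounds shown here, two measured steps bear on this change, since both alter the same benzyl ring. Putting trifluoromethyl onto that ring in place of hydrogen raised the number, as the step of a 4.4-fold higher number from compound 1 to compound 3 (0.64 log units; beyond the scatter) shows; exchanging 3-methylphenyl for 4-(trifluoromethyl)phenyl raised it further, as the step of a 6.6-fold higher number from compound 2 to compound 3 (0.82 log units; beyond the scatter) shows. Chloro is a different substituent from either, so the expectation for compound 4 is a number between those of compound 3 and compound 1, with the step of a 2.6-fold lower number from compound 3 to compound 4 (0.42 log units; beyond the scatter) expected. Compound 4 is therefore estimated at 40000 nM, with a range from 15000 nM to 110000 nM.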

Compound 4, half-maximal inhibitory concentration: 18000 nM
Compound 4: middle estimate off by 2.2-fold (0.35 log units), on the high side, within the range that was stated.
By their numbers in this assay, from the lowest: compounds 2, 4 and 1 (each within the scatter of the next); then compound 3.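

In this assay, the step (a 5.8-fold lower number from compound 3 to compound 4 (0.77 log units; beyond the scatter)) shows that the high number of compound 3 goes with trifluoromethyl in particular and not with every substituent at this place, para to a large group. Chloro at the same carbon stays within the scatter of the unsubstituted benzyl compound (a 1.3-fold lower number from compound 1 to compound 4 (0.12 log units; within the scatter)) and of the 3-methylphenyl compound (a 1.1-fold higher number from compound 2 to compound 4 (0.05 log units; within the scatter)), so among these compounds only trifluoromethyl moves the number beyond the scatter. Nothing measured here accounts for the difference between these two groups.

The compounds shown leave open whether any group on this carbon can bring the number clearly below those of compounds 1, 2 and 4. A methoxy group, an amine or a carboxylic acid at this place would begin to answer that.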